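Inversion of ring stereocentres in the opened-chain ester

The compounds below may be only part of what the source reports. "The series", "measured", "known", "first", "only" and "open" are said of these compounds alone.

Compound 1 `CC[C@H](C)C(=O)O[C@H]1CCC=C2C=C[C@H](C)[C@H](/C=C/C(=O)C[C@@H](O)CC(=O)O)[C@H]21` and compound 2 `CC[C@H](C)C(=O)O[C@H]1CCC=C2C=C[C@H](C)[C@H](COC(=O)CCCC(=O)O)C21` have been tested in an assay on microsomes from liver for inhibition of 3-hydroxy-3-methylglutaryl-coenzyme A reductase (Rattus norvegicus); on this read-out lower numbers stand for stronger inhibition and higher numbers for weaker inhibition. Compound 1 gives 630 nM in this assay. Compound 2 gives 7100 nM, the highest of the two numbers; the nearest is compound 1, with a lower number, a gap beyond the scatter. Among the compounds with values here, no pair differing in a single place has been measured, so no step size is known directly.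

Compound 3 `CC[C@H](C)C(=O)O[C@@H]1CCC=C2C=C[C@@H](C)[C@@H](COC(=O)CCCC(=O)O)[C@@H]21` is the next compound for this assay. Its relation to compound 2 is the two compounds have the same atoms and bonds; at least one stereo element is drawn with a configuration in one of them and without one in the other: 4 of 5 stereo elements differ; a stereocentre at a saturated ring carbon is drawn S in compound 2 and R in compound 3; a stereocentre at a saturated ring carbon is drawn S in compound 2 and R in compound 3; a stereocentre at a saturated ring carbon is drawn S in compound 2 and R in compound 3; a stereocentre at a saturated ring carbon is drawn without a configuration in compound 2 and S in compound 3. Within the data shown here, with no measured step of this kind on hand, the expectation rests on compound 2 alone, which already sits at 7100 nM, and on the change touching four of five stereo elements of the shared core. An upward step, beyond the scatter, is expected: a 2.8-fold higher number from compound 2 to compound 3 (0.45 log units; beyond the scatter). Compound 3 is estimated at 20000 nM, within 6000 nM to 70000 nM.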

Compound 3, half-maximal inhibitory concentration: 110000 nM
Compound 3: middle estimate off by 5.5-fold (0.74 log units), on the low side; the measured number lies above the stated range.
By their numbers in this assay, from the lowest: compound 1; then compound 2; then compound 3.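

With atoms and bonds unchanged, stereochemistry alone moves the read-out in this assay, giving a 15-fold higher number from compound 2 to compound 3 (1.19 log units; beyond the scatter), so the drawn configuration of the shared core matters for this opened-chain ester and not only the side chain. The step covers three saturated ring carbons going from S to R together with a fourth going from undrawn to S, so it belongs to the set of four stereo elements and not to any single centre. One limit applies to this reading: the fact that one of compounds 2 and 3 is drawn with a defined configuration and the other without, at the place where they differ.

Which of the four stereo elements carries the step remains open, as does the size of the step for any one of them changed alone. Also open, going by these compounds, is how these configurations behave with an amide in place of the chain ester, or with a longer chain ending in the carboxylic acid.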